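The source may report more compounds than this note shows. Statements on the series, on what has been measured and on what is new or still open speak of the compounds shown alone.

Measured so far:
Compound 1, `O=C1N/C(=N\c2ccc(Cl)cc2)S/C1=C/c1ccccc1O`: 1850 nM
Compound 2, `COc1ccc(/C=C2/S/C(=N/c3ccccc3C)NC2=O)cc1`: 1780 nM

These two compounds were tested in a functional assay on NCI-H460 cells (Homo sapiens) for antiproliferative activity; on this read-out higher numbers stand for weaker inhibition and lower numbers for stronger inhibition. Compound 1 gives 1850 nM and compound 2 gives 1780 nM. The two numbers sit within the usual scatter of each other, so neither compound stands apart from the other on this read-out; compound 2 simply shows the smaller of two nearly equal numbers.

The next compound, compound 3 `Cc1ccccc1/N=C1\NC(=O)/C(=C\c2ccc(N(C)C)cc2)S1`, is not yet measured in this assay. It differs from compound 2 in one place: dimethylamino in place of methoxy on an aromatic carbon. Going by the values given here, no measured pair shows this exchange, so its effect is unknown from the data. Compound 3 is expected to give a number close to that of compound 2, with at most a small step toward stronger inhibition that stays within the scatter, a 1.5-fold lower number from compound 2 to compound 3 (0.17 log units; within the scatter). The estimate for compound 3 is 1200 nM, with a range from 400 nM to 3600 nM.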

Compound 3, half-maximal inhibitory concentration: 650 nM
Compound 3: the middle estimate sits 1.8-fold (0.27 log units) above what was measured; the range from low to high includes it.
By their numbers in this assay, from the lowest: compound 3; then compounds 2 and 1 (each within the scatter of the next).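

Until this pair, no exchange between measured compounds could be read, but in this assay putting dimethylamino in place of methoxy on the aromatic carbon para to a large group gives a 2.7-fold lower number from compound 2 to compound 3 (0.44 log units; beyond the scatter) and so shows that the group at this position matters. The two groups count the same on hydrogen-bond donors, hydrogen-bond acceptors and net charge, and they differ by a single heavy atom, yet this one exchange moves the number toward stronger inhibition. Going by these compounds alone, nothing measured so far explains why the number moves. A single exchange cannot tell whether this step is specific to dimethylamino or would also appear with other groups at the same position. A plain amino group, a morpholine ring or a carboxylic acid there would help to settle that question.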